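Ring-closing an amine substituent on a shared purine-like core

The source may report more compounds than this note shows. Statements on the series, on what has been measured and on what is new or still open speak of the compounds shown alone.

Three compounds share one core and were tested in a functional assay on the whole organism for inhibition, with Rattus norvegicus as the target, at a dose of 25 mg/kg by the intraperitoneal route; a lower number here means less inhibition, a higher number more inhibition at the dose given (going by the name of the read-out). Compound 1 `CN(C)c1ncnc2c1ncn2Cc1ccccc1N` gives 0%. Compound 2 `CC(C)N(C)c1ncnc2c1ncn2CC1CC1` gives 32%. Compound 3 `CCN(CC)c1ncnc2c1ncn2CC1CC1` gives 0%. Compound 3 thus stands level with compound 1 at the digits shown, the two together at the bottom of the three numbers, while compound 2 sits higher by a margin beyond the usual scatter.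

The next compound, compound 4 `c1nc(N2CCCCC2)c2ncn(CC3CC3)c2n1`, differs from compound 3 in one place: piperidin-1-yl in place of diethylamino on an aromatic carbon.

Going by the values given here, only one measured step touches the same spot: a number 32 percentage points lower from compound 2 to compound 3 (beyond the scatter). That step shows that changing the two groups on this amine nitrogen can move the read-out by a large amount, but it does not show what closing them into a ring does. Because compound 3 gives 0%, the read-out cannot fall further, so any change would be upward. A modest rise is expected, a number 12 percentage points higher from compound 3 to compound 4 (beyond the scatter), with compound 4 estimated at 12% within a range of 0% to 35%.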

Compound 4, a percentage reported as inhibition, in the whole organism at one dose (the size of the read-out at that dose, not a potency): 28%
The estimate for compound 4 lay 16 percentage points below the measured number; measured number inside the range.
By their numbers in this assay, from the lowest: compounds 1 and 3 (each within the scatter of the next); then compounds 4 and 2 (each within the scatter of the next).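

Closing the diethylamino group into piperidin-1-yl restores a clear read-out in this assay (a number 28 percentage points higher from compound 3 to compound 4 (beyond the scatter)), so the result at compound 3 does not extend to every amine at this place on the shared core. A ring is therefore compatible with inhibition at the dose given, even though its open-chain counterpart shows none. The ring also matches the branched open-chain group, with a number 4 percentage points lower from compound 2 to compound 4 (within the scatter), which leaves diethylamino as the outlier among the three amines on the cyclopropylmethyl-bearing core.

The compounds shown leave open whether this holds for a smaller ring such as pyrrolidin-1-yl, or for a ring carrying an oxygen such as morpholin-4-yl. Nothing at hand accounts for the gap between the piperidin-1-yl and diethylamino compounds.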